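This account rests on a few compounds, and the source may have more. Where it says the series, first, only, none or still open, it means among the compounds named here.

In a functional assay on HT-29 cells (Homo sapiens) for inhibition, read by MTT assay, with a stated time of 48 h (a higher number here means a weaker inhibitor, a lower number a stronger inhibitor), compound 1 `COc1cc(-c2nnc(SC)n2-c2ccc(N(C)C)cc2)cc(OC)c1OC` gives > 60000 nM, which is a limit and not a number. Compound 2 `COc1cc(-c2nnc(SCc3ccccc3)n2-c2ccc(N(C)C)cc2)cc(OC)c1OC` gives > 60000 nM, also a limit. Compound 3 `COc1ccc(CSc2nnc(-c3cc(OC)c(OC)c(OC)c3)n2-c2ccc(N(C)C)cc2)cc1` gives > 60000 nM, again a limit. Among the measured compounds shown here, the series so far therefore stands at the limit of > 60000 nM in this assay, at which 3 of the 3 values shown sit.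

Compound 4 `COc1cc(-c2nnc(SCc3ccc(C)cc3)n2-c2ccc(N(C)C)cc2)cc(OC)c1OC` differs from compound 3 by having methyl in place of methoxy on an aromatic carbon, para to a large group (methyl in place of methoxy on an aromatic carbon). The nearest measured change is a step that the two limits leave unreadable from compound 2 to compound 3, and the other two are a step that the two limits leave unreadable from compound 1 to compound 2 and a step that the two limits leave unreadable from compound 1 to compound 3. None of them gives a size, so no step beyond the scatter is expected in either direction. The expected change is a step that the limit leaves unreadable from compound 3 to compound 4, with no direction favoured. Compound 4 is estimated at 70000 nM, with an expected range from 25000 nM to 120000 nM.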

Compound 4, half-maximal inhibitory concentration: 27500 nM
Compound 4: the middle estimate sits 2.5-fold (0.41 log units) above what was measured, within the range that was stated.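

In this assay, among the compounds shown here, the (4-methylbenzyl)sulfanyl group brings the first readable change: an at least 2.1-fold lower number from compound 3 to compound 4 (0.33 log units; beyond the scatter), an at least 2.1-fold lower number from compound 2 to compound 4 (0.33 log units; beyond the scatter) and an at least 2.1-fold lower number from compound 1 to compound 4 (0.33 log units; beyond the scatter). The earlier steps shown here cannot be read, whereas these show that, on this aromatic carbon para to a large group, methyl gives a stronger result than either methoxy or hydrogen. Compound 4 alone stands clear of the limit: the limit of > 60000 nM in this assay, at which 3 of the 4 values shown sit.

As far as these compounds go, whether ethyl, chlorine or a hydroxyl group at the same place would do better or worse stays open. From the compounds shown here alone, with a single true number, the size of the step also remains unknown.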